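Ethylsulfanyl for Pentyloxy: an Expected Step in Mice

A few compounds are considered here, and "the series" means these few. Any claim that something is new, unique, unknown or untested is made for them only; others in the source may bear on it.

Measured so far in a functional assay on the whole organism for activation, with Mus musculus as the target; on this read-out lower numbers stand for an effect already at smaller amounts and higher numbers for an effect only at larger amounts of compound:
compound 1, `CCCCOc1nc(N)c2[nH]c(=O)n(Cc3ccccc3)c2n1`: 0.1 mg/kg
compound 2, `CCCCCOc1nc(N)c2nc(O)n(Cc3ccccc3)c2n1`: 0.3 mg/kg
compound 3, `Nc1ncnc2c1nc(O)n2Cc1ccc(F)cc1`: 30 mg/kg

Compound 2 stands second highest of the three numbers. Its nearest neighbour is compound 1, whose number is lower by a margin beyond the usual scatter; the furthest is compound 3, whose number is far higher, again beyond the scatter. The contrast between compound 2 and compound 3 shows that a compound carrying an alkoxy chain on the shared core reaches its effect at a much smaller dose than one without such a chain, although those two differ in more than one place.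

Compound 4, `CCSc1nc(N)c2nc(O)n(Cc3ccccc3)c2n1`, has not yet been measured. It differs from compound 2 in one place: ethylsulfanyl in place of pentyloxy on an aromatic carbon. Among the measured compounds shown here, no step between two measured compounds matches this change. The three measured compounds suggest that a group in this place matters, and that shortening it from pentyloxy to butoxy did not hurt; replacing it with the much shorter ethylsulfanyl is expected to cost a modest amount, so the step of a 3.3-fold higher number from compound 2 to compound 4 (0.52 log units; beyond the scatter) is estimated to go toward a higher number. For compound 4 the expected value in this assay is 1 mg/kg, with a range from 0.2 mg/kg to 5 mg/kg.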

Compound 4, minimum effective dose: 0.1 mg/kg
Compound 4: middle estimate off by 10-fold (1.00 log units), on the high side; the measured number lies below the stated range.
By their numbers in this assay, from the lowest: compounds 1 and 4 (each within the scatter of the next); then compound 2; then compound 3.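

In this assay, ethylsulfanyl in place of pentyloxy gives a 3.0-fold lower number from compound 2 to compound 4 (0.48 log units; beyond the scatter), so a chain of 6 heavy atoms is not needed at this position, on an aromatic carbon between two ring nitrogen atoms, and a group of 3 heavy atoms serves at least as well. The earlier compounds shown here showed only alkoxy chains here, whereas this result shows that a group joined through sulfur is also tolerated. Compound 4 gives 0.1 mg/kg and compound 1, with butoxy in this place, gives 0.1 mg/kg, so the two cannot be told apart on this read-out. Nothing available explains the step. Ethoxy in this place would separate the effect of chain length from that of the sulfur atom, and the compounds shown leave that open. They also leave open how an amine such as ethylamino would behave here.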